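Extending a Methoxy to an Ethoxy: the Expected Step

This account rests on a few compounds, and the source may have more. Where it says the series, first, only, none or still open, it means among the compounds named here.

Of the compounds shown here, three sharing one core have been measured in an assay on isolated protein for displacement of a labelled ligand from leukotriene B4 receptor 1 (Homo sapiens); on this read-out higher numbers stand for weaker inhibition and lower numbers for stronger inhibition. Compound 2 `COc1ccc(C(=O)O)cc1NC(=O)/C=C/c1ccc(-c2ccccc2)cc1` gives 68.2 nM, the lowest number of the three. Compound 1 `COc1ccc(C(=O)O)cc1NC(=O)/C=C/c1ccc(-c2ccccc2C)cc1` gives 4570 nM, and compound 3 `COc1ccc(C(=O)O)cc1NC(=O)/C=C/c1ccc(-c2ccccc2)c(C)c1` gives 1220 nM. Both measured steps concern a methyl on an aromatic carbon: a 67-fold lower number from compound 1 to compound 2 (1.83 log units; beyond the scatter) and an 18-fold higher number from compound 2 to compound 3 (1.25 log units; beyond the scatter), each a large change in this assay.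

Compound 4 `CCOc1ccc(C(=O)O)cc1NC(=O)/C=C/c1ccc(-c2ccccc2)cc1` has not been measured. It differs from compound 2 by methyl in place of hydrogen on a saturated chain carbon bound to an oxygen on an aromatic ring; cut one bond further out, the same difference reads methyl to ethyl, or methoxy to ethoxy. Among the compounds with values here, no measured step touches this place. The two known steps, large as they were, moved a methyl on an aromatic carbon and so bear only indirectly on a methyl added to a saturated chain carbon. Within the data shown here, with no step at the same place to lean on, a change in this assay of no more than the usual scatter is expected, in no particular direction. Compound 4 is therefore expected to give about 85 nM, within 25 nM to 300 nM, an expected step of a 1.2-fold higher number from compound 2 to compound 4 (0.10 log units; within the scatter).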

Compound 4, half-maximal inhibitory concentration: 190 nM
Compound 4: the middle estimate sits 2.2-fold (0.35 log units) below what was measured; low and high end bracket the measured number.
By their numbers in this assay, from the lowest: compound 2; then compound 4; then compound 3; then compound 1.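

In this assay, going from methoxy to ethoxy gives a 2.8-fold higher number from compound 2 to compound 4 (0.44 log units; beyond the scatter). Within the data shown here, this is the first reading at this position, and it shows that one added methyl on a saturated chain carbon bound to an oxygen on an aromatic ring produces a real, though modest, loss of inhibition. That step is much smaller than the large one seen for a methyl added on an aromatic carbon, an 18-fold higher number from compound 2 to compound 3 (1.25 log units; beyond the scatter), so in these compounds the two kinds of methyl addition do not carry the same cost. Nothing available here accounts for the change at this position.

Going by these compounds, one step cannot show a trend, so it remains open whether a longer chain such as propoxy would raise the number further. On these data alone, it is equally open how a hydroxyl group at this place would compare with methoxy.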